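Adding a Formyl Group to Compound 3

A few compounds are considered here, and "the series" means these few. Any claim that something is new, unique, unknown or untested is made for them only; others in the source may bear on it.

Of the compounds shown here, three sharing one core have been measured in a functional assay on A2780 cells (Homo sapiens) for inhibition; a lower number here means a stronger inhibitor, a higher number a weaker inhibitor. Compound 1 `CCCC#Cc1cc(C)oc(=O)c1` gives 4800 nM. Compound 2 `CCCCCC/C=C/c1cc(C)oc(=O)c1` reaches only the limit of the assay, > 50000 nM. Compound 3 `Cc1cc(-c2ccccc2)cc(=O)o1` likewise gives no number but a limit, > 50000 nM. Compound 3 thus stands at the limit of > 50000 nM in this assay, at which 2 of the 3 values shown sit.

Compound 4 `Cc1cc(-c2ccc(C=O)cc2)cc(=O)o1` differs from compound 3 by a single change: formyl in place of hydrogen on an aromatic carbon. Going by the values given here, no measured pair shows what this change does, and compound 3 offers no number to step from. The expected step is an at least 1.2-fold lower number from compound 3 to compound 4 (0.09 log units; that floor lies within the scatter), which is no more than the usual scatter. Compound 4 is therefore estimated at 40000 nM, in a range from 8000 nM to 150000 nM, and may well again return only a limit.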

Compound 4, half-maximal inhibitory concentration: 19200 nM
Estimate against measurement, compound 4: 2.1-fold (0.32 log units) above; the measured number falls inside the stated range.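

Placing formyl on this aromatic carbon gives an at least 2.6-fold lower number from compound 3 to compound 4 (0.41 log units; beyond the scatter), the first step in the series that can be read, and it lies beyond the scatter. Compound 4 thus returns a number where compound 3 returned none. The true size of the step stays unknown because compound 3 gives only a limit: the limit of > 50000 nM in this assay, at which 2 of the 4 values shown sit.

From the compounds shown here alone, whether the gain belongs to formyl itself remains open, since an amine or a carboxylic acid at this place would test that. Going by these compounds, the effect of formyl on other carbons of this ring is equally open.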